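This account rests on a few compounds, and the source may have more. Where it says the series, first, only, none or still open, it means among the compounds named here.

Measured compounds:
- compound 1, `COc1ccc2cc(C(C)c3nnc4n3N=C(c3ccc(C(F)(F)F)cc3)CS4)ccc2c1`: 6900 nM
- compound 2, `CC(c1ccc(-c2ccccc2)c(F)c1)c1nnc2n1N=C(c1ccccc1)CS2`: 7400 nM
- compound 3, `CC(C)Cc1ccc(C(C)c2nnc3n2N=C(c2ccc(Br)cc2)CS3)cc1`: 9400 nM

All three were run in a functional assay on MCF7 cells (Homo sapiens) for inhibition, read by sulforhodamine B assay, with a stated time of 72 h; a higher number here means a weaker inhibitor, a lower number a stronger inhibitor. Compound 3 gives 9400 nM in this assay, compound 2 gives 7400 nM and compound 1 gives 6900 nM. The gaps from compound 3 to compound 2 and to compound 1 both fall within the usual scatter of repeated runs, so the three numbers sit together as one cluster and no ranking among them can be read from the data. Within the data shown here, no pair of measured compounds differs in a single place, so no single-point step has been measured.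

The next compound, compound 4, `CC(C)Cc1ccc(C(C)c2nnc3n2N=C(c2ccccc2)CS3)cc1`, is compound 3 with hydrogen in place of bromo on an aromatic carbon, which one bond further out reads as 4-bromophenyl to phenyl. Nothing measured here tells how a change of that kind acts in this assay. With compound 3 at 9400 nM and the series otherwise flat, the expectation for compound 4 is a step of a 1.2-fold higher number from compound 3 to compound 4 (0.07 log units; within the scatter) in this assay, that is, no step beyond the scatter and, if anything, a slightly higher number. Compound 4 is accordingly estimated at 11000 nM in this assay, with a range from 5000 nM to 25000 nM.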

Compound 4, half-maximal inhibitory concentration: 9700 nM
Compound 4: the middle estimate sits 1.1-fold (0.05 log units) above what was measured; the range from low to high includes it.
By their numbers in this assay, from the lowest: compounds 1, 2, 3 and 4 (each within the scatter of the next).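

Among these compounds, compounds 3 and 4 form the first pair that differs in one place, so this position can now be read directly. In this assay, hydrogen in place of bromo on an aromatic carbon, para to a large group, gives a 1.0-fold higher number from compound 3 to compound 4 (0.01 log units; within the scatter) and so leaves the read-out unmoved beyond the scatter, showing that with the shared core and the 4-isobutylphenyl side held fixed, the assay does not separate 4-bromophenyl from phenyl. No measurement available here bears on why the two compounds read alike.

The compounds shown leave open whether this position is insensitive to substitution in general, since bromo and hydrogen are the only two groups compared at this point on an otherwise unchanged compound, and a primary amine, a carboxylic acid or a longer alkyl chain at the same carbon could behave differently. As far as these compounds go, it also remains open whether the same exchange would read the same way on a compound with a different group at the other end of the core, such as the methoxynaphthyl of compound 1 or the fluorobiphenyl of compound 2.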